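The source may report more compounds than this note shows. Statements on the series, on what has been measured and on what is new or still open speak of the compounds shown alone.

In a functional assay on SR cells (Homo sapiens) for cytotoxicity, read by sulforhodamine B assay, with a stated time of 48 h, tested at 0.1 uM (on this read-out higher numbers stand for a weaker effect at the one concentration tested and lower numbers for a stronger effect), compound 1 `COc1cc(-c2cc(/C=C/C(=O)c3ccc(N)cc3)[nH]n2)cc(OC)c1OC` gives 87%, compound 2 `COc1cc(-c2cc(/C=C/C(=O)c3ccc(Cl)c(Cl)c3)[nH]n2)cc(OC)c1OC` gives 89%, and compound 3 `COc1ccc(C(=O)/C=C/c2cc(-c3cc(OC)c(OC)c(OC)c3)n[nH]2)cc1OC` gives 81%, the lowest of the three numbers, though its gaps to both neighbours, a number 6 percentage points lower from compound 1 to compound 3 (within the scatter) and a number 8 percentage points lower from compound 2 to compound 3 (within the scatter), lie within the scatter, as does a number 2 percentage points higher from compound 1 to compound 2 (within the scatter). Compound 4 `COc1ccc(C(=O)/C=C/c2cc(-c3cc(OC)c(OC)c(OC)c3)n[nH]2)cc1` differs from compound 3 by hydrogen in place of methoxy on an aromatic carbon. All three measured steps exchange the ring on the carbonyl carbon, the same ring that is altered here, and none of them moved the read-out beyond the scatter. Compound 4 is therefore expected to show a step of a number 2 percentage points higher from compound 3 to compound 4 (within the scatter), nothing beyond the scatter. In this assay compound 4 is estimated at 83%, between 70% and 95%.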

Compound 4, a percentage reported as activity, at one concentration (the size of the read-out at that concentration, not a potency): 83%
Beside the measured number, compound 4's estimate shows no gap at the digits printed; the measured number falls inside the stated range.
By their numbers in this assay, from the lowest: compounds 3, 4, 1 and 2 (each within the scatter of the next).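

Hydrogen in place of methoxy on this ring, which turns 3,4-dimethoxyphenyl into 4-methoxyphenyl, alters a single group rather than the whole ring, and in this assay it gives a number 2 percentage points higher from compound 3 to compound 4 (within the scatter). Methoxy in place of amino on the same ring gives a number 4 percentage points lower from compound 1 to compound 4 (within the scatter), and 4-methoxyphenyl in place of 3,4-dichlorophenyl gives a number 6 percentage points lower from compound 2 to compound 4 (within the scatter), so this ring has tolerated every exchange shown without a step beyond the scatter. No available evidence accounts for these steps. The compounds shown leave open whether a carboxylic acid, a dimethylamino group or a longer alkoxy chain on this ring would produce a step beyond the scatter.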